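Aryl and alkyl groups on the piperidine-bound carbon

The source may report more compounds than this note shows. Statements on the series, on what has been measured and on what is new or still open speak of the compounds shown alone.

Compound 1 `Cc1ccc2c(NCc3ccc(NC(=O)C4CCN(Cc5cccc(F)c5)CC4)cc3)nc(N(C)C)nc2c1` is one of three measured analogues sharing a core and differing only at a saturated chain carbon bound to an amine nitrogen in a ring. In a functional assay on SV5A8 cells (Homo sapiens) for cytotoxicity (a lower number here means a stronger inhibitor, a higher number a weaker inhibitor), compound 1 gives only a limit, > 4170 nM. Compound 2 `Cc1ccc2c(NCc3ccc(NC(=O)C4CCN(Cc5ncc[nH]5)CC4)cc3)nc(N(C)C)nc2c1` likewise gives only a limit in this assay, > 20000 nM. Compound 3 `CCCCN1CCC(C(=O)Nc2ccc(CNc3nc(N(C)C)nc4cc(C)ccc34)cc2)CC1` also gives only a limit in this assay, > 10500 nM. Three limits leave a step that the two limits leave unreadable from compound 1 to compound 3 and a step that the two limits leave unreadable from compound 2 to compound 3 without readable size, as with a step that the two limits leave unreadable from compound 1 to compound 2. Compound 4 `Cc1ccc2c(NCc3ccc(NC(=O)C4CCN(Cc5cc(Cl)ccn5)CC4)cc3)nc(N(C)C)nc2c1` differs from compound 3 by 4-chloropyridin-2-yl in place of propyl on a saturated chain carbon bound to an amine nitrogen in a ring. Since both measured exchanges of propyl for an aromatic ring at this carbon are unreadable, no step beyond the scatter can be foreseen in this assay, and a further limit is the likelier outcome. Compound 4 is therefore expected at 15000 nM (range 4000 nM to 60000 nM), the step that the limit leaves unreadable from compound 3 to compound 4 being an estimate only.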

Compound 4, half-maximal inhibitory concentration: > 5400 nM
Compound 4 ended at the assay's limit; the forecaster's own chance of this, stated with the estimate: 80%; the middle value does not contradict the limit.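

Compound 4 gives only a limit in this assay, > 5400 nM. The steps to it from compound 1, compound 2 and compound 3 cannot be read. The compounds shown leave open whether the group at this carbon changes this assay at all.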